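Trading a Methoxyphenyl for a Difluorophenyl

This account rests on a few compounds, and the source may have more. Where it says the series, first, only, none or still open, it means among the compounds named here.

Measured so far:
Compound 1, `COc1ccc(C(=O)/C=C/c2cc(-c3cc(OC)c(OC)c(OC)c3)n[nH]2)cc1OC`: in a functional assay on HOP-62 cells (Homo sapiens) for inhibition, read by sulforhodamine B assay, with a stated time of 48 h (a higher number here means that more compound is tolerated, a lower number that less compound is tolerated), compound 1 gives 5350 nM.
Compound 2, `COc1ccc(C(=O)/C=C/c2cc(-c3cc(OC)c(OC)c(OC)c3)n[nH]2)cc1`: in this assay compound 2 gives 8070 nM.

Within the data shown here, compound 2 holds the highest of the two numbers, and its only neighbour is compound 1; the step between them, a 1.5-fold higher number from compound 1 to compound 2 (0.18 log units; within the scatter), came from a hydrogen in place of a methoxy on an aromatic carbon and stays within the scatter, so the two compounds cannot be told apart on these numbers.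

Compound 3, `COc1cc(-c2cc(/C=C/C(=O)c3ccc(F)c(F)c3)[nH]n2)cc(OC)c1OC`, is not yet measured. It differs from compound 2 in one place: 3,4-difluorophenyl in place of 4-methoxyphenyl on a carbonyl carbon. Among the measured compounds shown here, the single measured step, a 1.5-fold higher number from compound 1 to compound 2 (0.18 log units; within the scatter), touches a methoxy on an aromatic carbon and not the whole aromatic ring on the carbonyl carbon, so it bears on the new change only loosely, and it was itself within the scatter. With nothing pointing either way, the expected step in this assay is none beyond the scatter, a 1.0-fold lower number from compound 2 to compound 3 (0.00 log units; within the scatter). Compound 3 is therefore estimated at 8000 nM, with a range from 3000 nM to 22000 nM.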

Compound 3, concentration lethal to 50% of the cells: > 100000 nM
Compound 3 was reported as a limit (the forecaster's own chance of this, stated with the estimate: 5%); at least 12-fold (1.09 log units) between middle value and limit.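

The ring on the carbonyl carbon matters far more in this assay than the earlier pair suggested, where losing one methoxy gave only a 1.5-fold higher number from compound 1 to compound 2 (0.18 log units; within the scatter). Replacing the whole ring has a large effect: 3,4-difluorophenyl in place of 4-methoxyphenyl gives an at least 12-fold higher number from compound 2 to compound 3 (1.09 log units; beyond the scatter), and 3,4-difluorophenyl in place of 3,4-dimethoxyphenyl gives an at least 18-fold higher number from compound 1 to compound 3 (1.27 log units; beyond the scatter). In both steps, much more compound is tolerated, and since compound 3 is reported only as a limit, the full size of these steps remains unknown: the limit of > 100000 nM in this assay, at which 1 of the 3 values shown sits.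

The compounds shown leave open whether the large step comes from losing the methoxy groups or from gaining the fluorines, as the change does both at once. A plain phenyl or a 4-fluorophenyl on the carbonyl carbon would help separate the two, and a 3,4-dichlorophenyl would show whether another halogen behaves in the same way.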